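Two Double Bonds Enter a Long Chain

This account rests on a few compounds, and the source may have more. Where it says the series, first, only, none or still open, it means among the compounds named here.

Among the measured compounds shown here, this series is followed in an ADME assay on the whole organism (plasma) for pharmacokinetics, with Homo sapiens as the target (a lower number here means that the compound disappears faster, a higher number that the compound lasts longer), and only one compound so far gives a true number. Compound 2, `CCCCCCCCCCCCCCCC(=O)OCC1C=CC(n2cc(C)c(=O)[nH]c2=O)O1`, has a half-life of 4 h. Compound 1, `Cc1cn(C2C=CC(COP(=O)(O)OCC3C=CC(n4cc(C)c(=O)[nH]c4=O)O3)O2)c(=O)[nH]c1=O`, gives only a limit of the assay, > 24 h. Compound 3, `CCCCCCCCCCCCCCCCNC(=O)OCC1C=CC(n2cc(C)c(=O)[nH]c2=O)O1`, likewise gives only a limit, > 24 h. Compound 2 therefore holds the single numerical half-life among the three, and it serves as the starting point here.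

Compound 4, `CCCC/C=C/C/C=C/CCCCCCCC(=O)OCC1C=CC(n2cc(C)c(=O)[nH]c2=O)O1`, has not yet been measured. It differs from compound 2 in one place: nona-1,4-dien-1-yl in place of octyl on a saturated chain carbon, seven bonds along the chain from a carbonyl carbon. In words, nona-1,4-dien-1-yl stands in place of octyl on a saturated chain carbon, seven bonds along the chain from a carbonyl carbon. The shared core and the carbonyl stay as they are.

For the measured compounds named here, no measured pair differs in one place, so there is no earlier step to show how large such a change might be. The expected change no change at the digits printed from compound 2 to compound 4 (within the scatter) is none beyond the usual scatter, with neither direction favoured. This expectation starts from compound 2 at 4 h and carries a wide margin. For compound 4 the estimated half-life is 4 h, with an expected range of 1.5 h to 11 h.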

Compound 4, half-life: 2 h
Compound 4: middle estimate off by 2.0-fold (0.30 log units), on the high side; the measured number falls inside the stated range.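

In this assay, placing nona-1,4-dien-1-yl in place of octyl on a saturated chain carbon, seven bonds along the chain from a carbonyl carbon, gives a 2.0-fold lower number from compound 2 to compound 4 (0.30 log units; within the scatter). Among the compounds shown here, this is the only step that compares compounds differing in one place, and it shows that at this position a chain carrying two double bonds cannot be told apart from the saturated octyl chain by this read-out, given the ordinary spread of repeat measurements. It also gives the series a second true number to set beside the one already in hand, which matters for a small set in which much of the data stops at the edge of the assay: the limit of > 24 h in this assay, at which 2 of the 4 values shown sit.

The step leaves open how a chain with a single double bond would compare at this place, and whether the double bonds and the change in chain length would each leave the half-life as unchanged on their own. A shorter chain, a much longer chain, or a chain ending in an amine or a carboxylic acid could still behave quite differently here.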